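Fluoro to bromo on the benzylidene ring of a diketopiperazine series

The source may report more compounds than this note shows. Statements on the series, on what has been measured and on what is new or still open speak of the compounds shown alone.

Measured compounds:
compound 1 `COc1ccccc1/C=c1/[nH]c(=O)/c(=C\c2ccccc2OC)[nH]c1=O`: "not active" (no number reported)
compound 2 `COc1ccccc1/C=c1\c(=O)[nH]/c(=C/c2cccc(Cl)c2Cl)c(=O)n1C`: 300 nM
compound 3 `C=CCn1c(=O)/c(=C\c2cccc(F)c2)[nH]c(=O)/c1=C\c1ccccc1OC`: 27200 nM

Three compounds share a core and differ in their substituents. In a functional assay on Huh-7 cells (Homo sapiens) for cytotoxicity, read by CCK-8 assay, with a stated time of 72 h (on this read-out lower numbers stand for stronger inhibition and higher numbers for weaker inhibition), compound 1 gives "not active" (no number reported), with no number reported. In this assay compound 2 gives 300 nM. Compound 3 gives 27200 nM in this assay, the highest of the two numbers shown; compound 2 lies a long way lower, and that gap is beyond the scatter.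

Compound 4 `C=CCn1c(=O)/c(=C\c2cccc(Br)c2)[nH]c(=O)/c1=C\c1ccccc1OC` has not yet been measured in this assay. It differs from compound 3 in one place: bromo in place of fluoro on an aromatic carbon. Among the measured compounds shown here, the data hold no measured step between two compounds that differ only in this way, so there is no direct guide for the size or direction of the step.

With that gap in the data, compound 4 is expected to stay close to compound 3, and the step from a 1.8-fold lower number from compound 3 to compound 4 (0.26 log units; within the scatter) is estimated as small, not beyond the scatter. The estimate for compound 4 in this assay is 15000 nM, within 4000 nM to 60000 nM.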

Compound 4, half-maximal inhibitory concentration: 2300 nM
Estimate against measurement, compound 4: 6.5-fold (0.81 log units) above, and the stated range ends above it.
By their numbers in this assay, from the lowest: compound 2; then compound 4; then compound 3.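

Among the compounds shown here, this is the first measured step at this position: in this assay, going from 3-fluorophenyl to 3-bromophenyl gives a 12-fold lower number from compound 3 to compound 4 (1.07 log units; beyond the scatter) and that step is large. The position is therefore sensitive to which halogen it carries, since exchanging one heavy atom, with no hydrogen-bond donor or acceptor entering or leaving, is enough to shift the number well beyond the scatter. The data hold no measurement that bears on why the exchange has this effect.

The compounds shown leave open where chloro, iodo, an amine or a carboxylic acid at this place would fall relative to compound 3 and compound 4. They also leave open whether the same exchange gives a step of like size in a compound without the allyl group.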